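Adding Isopropyl to an Amine Nitrogen: Expected Cytotoxicity

The source may report more compounds than this note shows. Statements on the series, on what has been measured and on what is new or still open speak of the compounds shown alone.

Measured compounds:
Compound 1, `N=C(N)c1ccc2oc(-c3cccc(OCCCOc4ccccc4)c3)cc2c1`, 10300 nM
Compound 2, `CC(C)NC(=N)c1ccc2oc(-c3cccc(OCCCOc4ccccc4)c3)cc2c1`, 26500 nM
Compound 3, `N=C(N)c1ccc2oc(-c3cccc(OCCCCCCOc4ccccc4)c3)cc2c1`, 3100 nM

All three were tested in an ADME assay on L6 cells (Rattus norvegicus) for cytotoxicity, read by resazurin assay, with a stated time of 70 h; on this read-out lower numbers stand for stronger inhibition and higher numbers for weaker inhibition. In this assay compound 1 gives 10300 nM, compound 2 gives 26500 nM and compound 3 gives 3100 nM. Compound 3 has the lowest number of the three, and its steps to the other two lie beyond the scatter.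

Two single changes connect these compounds. From compound 1 to compound 2 the change is isopropyl in place of hydrogen on an amine nitrogen, and it gave a 2.6-fold higher number from compound 1 to compound 2 (0.41 log units; beyond the scatter). From compound 1 to compound 3 the change is 3-phenoxypropyl in place of phenoxy on a saturated chain carbon, three bonds along the chain from an oxygen on an aromatic ring, and it gave a 3.3-fold lower number from compound 1 to compound 3 (0.52 log units; beyond the scatter).

Compound 4, `CC(C)NC(=N)c1ccc2oc(-c3cccc(OCCCCCCOc4ccccc4)c3)cc2c1`, has not yet been measured. It differs from compound 3 by isopropyl in place of hydrogen on an amine nitrogen. This is the same change that was made from compound 1 to compound 2, at the same place, and it occurs twice among these compounds. The two cores differ by 3-phenoxypropyl in place of phenoxy on a saturated chain carbon, three bonds along the chain from an oxygen on an aromatic ring, so the change is seen on a longer chain in compound 4 than in compound 2.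

Among the measured compounds shown here, with only one earlier instance to rest on, the step is expected to repeat: from compound 3 to compound 4 an estimated 2.6-fold higher number from compound 3 to compound 4 (0.41 log units; beyond the scatter) in this assay, resting on a 2.6-fold higher number from compound 1 to compound 2 (0.41 log units; beyond the scatter). On that basis compound 4 is expected to give about 8000 nM in this assay, with a likely range from 4000 nM to 16000 nM.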

Compound 4, half-maximal inhibitory concentration: 7400 nM
For compound 4 the middle estimate is 1.1-fold (0.03 log units) above the measured one; low and high end bracket the measured number.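

In this assay the isopropyl change gave a 2.4-fold higher number from compound 3 to compound 4 (0.38 log units; beyond the scatter), so on the core with the longer chain it behaved as it had on the core with the shorter chain: the same change on two cores in this assay, a 2.6-fold higher number (0.41 log units; beyond the scatter) from compound 1 to compound 2 and a 2.4-fold higher number (0.38 log units; beyond the scatter) from compound 3 to compound 4, 1.1-fold (0.03 log units) apart, within the scatter of two such steps

The chain change, seen here on the two compounds carrying isopropyl, gave a 3.6-fold lower number from compound 2 to compound 4 (0.55 log units; beyond the scatter), and it also matched its earlier instance: the same change on two cores in this assay, a 3.3-fold lower number (0.52 log units; beyond the scatter) from compound 1 to compound 3 and a 3.6-fold lower number (0.55 log units; beyond the scatter) from compound 2 to compound 4, 1.1-fold (0.03 log units) apart, within the scatter of two such steps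

Within these four compounds, then, each change moved the number by about the same amount whichever form the other part of the molecule took, but each comparison rests on just two steps in this assay, so this does not show that the pattern holds on other cores or explain why either change moves the number.

The compounds shown leave open whether a different group on the same amine nitrogen, such as methyl or cyclopentyl, would give a step of similar size. Among the compounds shown here, they also leave open whether the isopropyl step would stay the same on a chain longer than the one in compound 3.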